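PLK2 series: amide nitrogen substitution on compound 2

A few compounds are considered here, and "the series" means these few. Any claim that something is new, unique, unknown or untested is made for them only; others in the source may bear on it.

Measured so far:
compound 1 `CCCNS(=O)(=O)c1ccc(Nc2ncc3c(n2)N(C2CCCC2)[C@H](CC)C(=O)N3C)cc1`, 17.8 nM
compound 2 `CCC1C(=O)N(C)c2cnc(-n3ccc4cc(C(N)=O)ccc43)nc2N1c1ccn(C)n1`, 384 nM
compound 3 `CC[C@@H]1C(=O)N(C)c2cnc(-n3ccc4cc(C(=O)NC(C)C)ccc43)nc2N1C1CCCC1`, 17.4 nM

In an assay for inhibition of serine/threonine-protein kinase PLK2 (Homo sapiens), read by FRET and Z'-LYTE, with a stated time of 1 h (on this read-out higher numbers stand for weaker inhibition and lower numbers for stronger inhibition), compound 2 gives the highest number of the three, and its gaps to compound 1 and to compound 3 both lie beyond the scatter. Compound 4 `CCC1C(=O)N(C)c2cnc(-n3ccc4cc(C(=O)NC(C)C)ccc43)nc2N1c1ccn(C)n1` is not yet measured. It differs from compound 2 in one place: isopropyl in place of hydrogen on an amide-type nitrogen. Compound 3 carries the same isopropylcarbamoyl group and gives 17.4 nM, but it also differs from compound 2 at the other ring nitrogen, so the amide change cannot be separated from the data in hand. The step is expected to lower the number, by a 3.2-fold lower number from compound 2 to compound 4 (0.51 log units; beyond the scatter). Compound 4 is expected to give 120 nM, within the range 30 nM to 500 nM.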

Compound 4, half-maximal inhibitory concentration: 125 nM
For compound 4 the middle estimate is 1.0-fold (0.02 log units) below the measured one, and the stated range covers the measured number.
By their numbers in this assay, from the lowest: compounds 3 and 1 (each within the scatter of the next); then compound 4; then compound 2.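

In this assay, isopropyl in place of hydrogen on the amide-type nitrogen gives a 3.1-fold lower number from compound 2 to compound 4 (0.49 log units; beyond the scatter) with the rest of compound 2 held fixed. This isolates the amide change, which compound 3 could not do, and shows that this nitrogen accepts a branched group without a loss in this assay. Nothing measured here accounts for the step.

From the compounds shown here alone, whether a methyl, a longer chain or a cyclopropyl group on this nitrogen would go further remains open. So does whether the same change gives a step of similar size with cyclopentyl on the other ring nitrogen.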